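Acetyl in place of pyridinylcarbonyl on the shared core

The source may report more compounds than this note shows. Statements on the series, on what has been measured and on what is new or still open speak of the compounds shown alone.

Three analogues of one core have been measured. Compound 1 `CCCc1nc(CC)c(C(=O)CCN(C(=O)c2ccccc2)c2ccccc2)n1Cc1ccc(-c2ccccc2S(=O)(=O)NC(=O)OCCC(C)C)cc1F` gives 0.18 nM; 0.06 nM (2 entries) in an assay on isolated protein for inhibition of Type-2 angiotensin II receptor (Rattus norvegicus) (on this read-out lower numbers stand for stronger inhibition and higher numbers for weaker inhibition), as its repeated entries show (the several entries of compound 1 in this assay, 0.18 nM; 0.06 nM (2 entries)). Compound 2 `CCCc1nc(CC)c(C(=O)CCN(C(=O)c2cccnc2)c2cccnc2)n1Cc1ccc(-c2ccccc2S(=O)(=O)NC(=O)OCCC(C)C)cc1F` gives 0.22 nM, the highest of the two single numbers, and compound 3 `CCCc1nc(CC)c(C(=O)CCN(C(=O)c2cccnc2)c2ccccn2)n1Cc1ccc(-c2ccccc2S(=O)(=O)NC(=O)OCCC(C)C)cc1F` gives 0.16 nM; the step of a 1.4-fold lower number from compound 2 to compound 3 (0.14 log units; within the scatter) lies within the scatter. Compound 4 `CCCc1nc(CC)c(C(=O)CCN(C(C)=O)c2cccnc2)n1Cc1ccc(-c2ccccc2S(=O)(=O)NC(=O)OCCC(C)C)cc1F` is not yet measured. It differs from compound 2 by methyl in place of pyridin-3-yl on a carbonyl carbon. Going by the values given here, no measured step touches the carbonyl substituent; the only single-point step, a 1.4-fold lower number from compound 2 to compound 3 (0.14 log units; within the scatter), was small. A modest step is therefore expected, with the number for compound 4 estimated at 0.4 nM (range 0.1 nM to 1.5 nM), meaning an expected step of a 1.8-fold higher number from compound 2 to compound 4 (0.26 log units; within the scatter).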

Compound 4, half-maximal inhibitory concentration: 3 nM
For compound 4 the middle estimate is 7.5-fold (0.88 log units) below the measured one; the measured number lies above the stated range.
By their numbers in this assay, from the lowest: compounds 3 and 2 (each within the scatter of the next); then compound 4.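

In this assay, methyl in place of pyridin-3-yl on a carbonyl carbon gives a 14-fold higher number from compound 2 to compound 4 (1.13 log units; beyond the scatter), the only step shown that lies beyond the scatter. This position is therefore sensitive to change, which the swap on the amide-type nitrogen between compound 2 and compound 3 did not reveal for that site. The step is also wider than the spread between repeat entries of one analogue: the several entries of compound 1 in this assay, 0.18 nM; 0.06 nM (2 entries)

As far as these compounds go, what in the change produces the step remains unknown. From the compounds shown here alone, it is also open whether a longer chain such as propyl, or a saturated ring such as cyclohexyl, on that carbonyl carbon would bring the number back towards that of compound 2.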